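Chloro for Fluoro on a Shared Core: What to Expect

A few compounds are considered here, and "the series" means these few. Any claim that something is new, unique, unknown or untested is made for them only; others in the source may bear on it.

Of the compounds shown here, three have been measured in a functional assay on the whole organism (strain Wistar) for inhibition, with Rattus norvegicus as the target, read by paw edema, with a stated time of 30 min, at a dose of 50 mg/kg by the oral route; on this read-out higher numbers stand for more inhibition at the one dose given (going by the name of the read-out) and lower numbers for less inhibition. Compound 1 `Fc1ccc(C2=NN(c3ccccc3)C(c3cn(-c4ccccc4)nc3-c3ccc(Cl)c(Cl)c3)C2)cc1` gives 44.7%. Compound 2 `Clc1ccc(C2=NN(c3ccccc3)C(c3cn(-c4ccccc4)nc3-c3ccc(Cl)c(Cl)c3)C2)cc1` differs from compound 1 by chloro in place of fluoro on an aromatic carbon; in this assay compound 2 gives 45.7%, and the step of a number 1 percentage points higher from compound 1 to compound 2 (within the scatter). Compound 3 `O=[N+]([O-])c1ccc(N2N=C(c3ccc(F)cc3)CC2c2cn(-c3ccccc3)nc2-c2ccc(Cl)c(Cl)c2)cc1` carries a different core, which is set apart from compound 1 by nitro in place of hydrogen on an aromatic carbon; in this assay compound 3 gives 45.7%, the step being a number 1 percentage points higher from compound 1 to compound 3 (within the scatter). Compound 4 `O=[N+]([O-])c1ccc(N2N=C(c3ccc(Cl)cc3)CC2c2cn(-c3ccccc3)nc2-c2ccc(Cl)c(Cl)c2)cc1` has not yet been measured. It differs from compound 3 by chloro in place of fluoro on an aromatic carbon, the same change at the same place as that from compound 1 to compound 2. Because the step of a number 1 percentage points higher from compound 1 to compound 2 (within the scatter) stayed within the scatter, compound 4 is expected to move by a number 0.8 percentage points higher from compound 3 to compound 4 (within the scatter) from compound 3. Compound 4 is therefore estimated at 46.5%, with a range from 37% to 56%.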

Compound 4, a percentage reported as inhibition, in the whole organism at one dose (the size of the read-out at that dose, not a potency): 48.9%
Compound 4: middle estimate off by 2.4 percentage points, on the low side; measured number inside the range.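

In this assay, chloro in place of fluoro on the core of compound 3 gives a step of a number 3.2 percentage points higher from compound 3 to compound 4 (within the scatter), which agrees with the earlier step on the core of compound 1: the same change on two cores in this assay, a number 1 percentage points higher (within the scatter) from compound 1 to compound 2 and a number 3.2 percentage points higher (within the scatter) from compound 3 to compound 4, 2.2 percentage points apart, within the scatter of two such steps

Nitro in place of hydrogen, set on the chloro compound, gives a step of a number 3.2 percentage points higher from compound 2 to compound 4 (within the scatter), which agrees with its earlier step too: the same change on two cores in this assay, a number 1 percentage points higher (within the scatter) from compound 1 to compound 3 and a number 3.2 percentage points higher (within the scatter) from compound 2 to compound 4, 2.2 percentage points apart, within the scatter of two such steps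

Each change therefore carries between these two cores, but every step lies within the scatter, so this shows no measurable effect of either change and says nothing about other cores.

On these data alone, whether a methoxy group or an amine in place of the fluoro or chloro would move the number beyond the scatter stays open. So does the behaviour of these compounds at any other dose.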